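Replacing the Group on the Sulfonyl Sulfur of Compound 2

The source may report more compounds than this note shows. Statements on the series, on what has been measured and on what is new or still open speak of the compounds shown alone.

In a functional assay on DU-145 cells (Homo sapiens) for inhibition, read by trypan blue exclusion, with a stated time of 96 h (on this read-out lower numbers stand for stronger inhibition of growth and higher numbers for weaker inhibition of growth), compound 1 (`CCOc1ccc(/C=C(\C(=O)c2ccc(Cl)cc2)S(=O)(=O)Cc2ccc(C)cc2)cc1OC`) gives 10000 nM as its result. Compound 2 (`O=C(/C(=C\c1c(O)cc(O)cc1O)S(=O)(=O)c1ccc(Br)cc1)c1ccc(Cl)cc1`) is reported only as > 100000 nM and this is a limit of the assay, not a number. Compound 3 (`Cc1ccc(CS(=O)(=O)/C(=C/c2c(O)cc(O)cc2O)C(=O)c2ccc(Cl)cc2)cc1`) has 4-methylbenzyl in place of 4-bromophenyl on a sulfonyl sulfur and is otherwise the same as compound 2. For the measured compounds named here, no measured step shows what such a change does in this assay and the size of any shift remains uncertain. A move beyond the scatter is nonetheless expected, towards stronger inhibition of growth, and the estimated step is an at least 5.0-fold lower number from compound 2 to compound 3 (0.69 log units; beyond the scatter) on that reading. For compound 3 the expected value is 20000 nM with an estimated range from 3000 nM to 100000 nM around it.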

Compound 3, concentration for 50% growth inhibition: > 100000 nM
Compound 3: a limit, no number (the forecaster's own chance of this, stated with the estimate: 35%); at least 5.0-fold (0.69 log units) between middle value and limit.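

In this assay, putting 4-methylbenzyl in place of 4-bromophenyl on the sulfonyl sulfur does not bring compound 3 into the measurable range, as its result is also a limit and not a number. As far as these compounds go, the step from compound 2 to compound 3 cannot be read, and whether this change moves the result at all stays unknown, because both compounds sit at the same limit: the limit of > 100000 nM in this assay, at which 2 of the 3 values shown sit. With 4-methylbenzyl on the sulfonyl sulfur in both, 2,4,6-trihydroxyphenyl in place of 4-ethoxy-3-methoxyphenyl on the double-bonded chain carbon gives a readable step, an at least 10-fold higher number from compound 1 to compound 3 (1.00 log units; beyond the scatter).

Still open, from the compounds shown here alone, is whether any group on the sulfonyl sulfur yields a number while 2,4,6-trihydroxyphenyl is kept. Also open, going by these compounds, is what 4-bromophenyl or a plain methyl on that sulfur would give alongside 4-ethoxy-3-methoxyphenyl.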